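A Bromo Analogue Beside Three Compounds at the Ceiling

The compounds below may be only part of what the source reports. "The series", "measured", "known", "first", "only" and "open" are said of these compounds alone.

Of the compounds shown here, three sharing one core have been tested in an ADME assay on A549 cells (Homo sapiens) for cytotoxicity, read by MTT assay, with a stated time of 48 h; a lower number here means a stronger inhibitor of growth, a higher number a weaker inhibitor of growth. Compound 1 `O=C(/C=C\c1cccc(O)c1)N1N=C(c2ccncc2)OC1c1c[nH]c2ccccc12` carries a hydroxy group on its outer ring, and in this assay compound 1 gives only a limit, > 30 ug/mL, not a number. Compound 2 `O=C(/C=C\c1cccc(F)c1)N1N=C(c2ccncc2)OC1c1c[nH]c2ccccc12` carries fluoro in place of that hydroxy, and compound 2 likewise gives a limit of > 30 ug/mL. Compound 3 `O=C(/C=C\c1cccc(Cl)c1)N1N=C(c2ccncc2)OC1c1c[nH]c2ccccc12` carries chloro there, and compound 3 also reaches only a limit of > 30 ug/mL. Because all three sit at the limit of > 30 ug/mL in this assay, at which 3 of the 3 values shown sit, the steps between them, a step that the two limits leave unreadable from compound 1 to compound 2, a step that the two limits leave unreadable from compound 1 to compound 3 and a step that the two limits leave unreadable from compound 2 to compound 3, cannot be sized. Compound 3 thus stands where every measured compound stands, at the ceiling of this assay.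

The untested compound 4 `O=C(/C=C\c1cccc(Br)c1)N1N=C(c2ccncc2)OC1c1c[nH]c2ccccc12` differs from compound 3 by bromo in place of chloro on an aromatic carbon. Of the measured steps, a step that the two limits leave unreadable from compound 2 to compound 3 and a step that the two limits leave unreadable from compound 1 to compound 3 bear on this change, but neither could be read, so no direction can be drawn from them; all that the data show is that three different groups on that aromatic carbon each ended at a limit. Compound 4 is therefore expected to behave the same way, with an estimated step that the limit leaves unreadable from compound 3 to compound 4. For compound 4 the expected value is 40 ug/mL, within the range 15 ug/mL to 100 ug/mL, most likely again reported only as a limit.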

Compound 4, concentration for 50% growth inhibition: > 30 ug/mL
Compound 4: a limit, no number (the forecaster's own chance of this, stated with the estimate: 80%); the middle value is on the limit's open side.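

In this assay compound 4 gives > 30 ug/mL as a limit, not a number. Its steps to compound 1, compound 2 and compound 3 therefore cannot be read: the limit of > 30 ug/mL in this assay, at which 4 of the 4 values shown sit. The compounds shown leave open how strongly any of the four inhibits growth, and whether the group on the outer ring changes that at all.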